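From anilide to benzylamide on a shared core

The source may report more compounds than this note shows. Statements on the series, on what has been measured and on what is new or still open speak of the compounds shown alone.

Compound 1, `COc1ccc2c(=O)c(/C=C/C(=O)NCc3cccc(F)c3)coc2c1`, gives 28600 nM in a functional assay (QGY7701 cells, Homo sapiens) for inhibition, read by MTT assay, with a stated time of 48 h; a higher number here means a weaker inhibitor, a lower number a stronger inhibitor.
Compound 2, `COc1ccc2c(=O)c(/C=C/C(=O)Nc3ccccc3)coc2c1`, gives 14000 nM in this assay.
Compound 3, `Cc1ccc(CNC(=O)/C=C/c2coc3cc(O)ccc3c2=O)cc1`, gives 24900 nM in this assay.

Compound 2 holds the lowest of the three numbers, though its gap to compound 3 lies within the scatter and only the gap to compound 1 lies beyond it. Compound 4, `COc1ccc2c(=O)c(/C=C/C(=O)NCc3ccccc3)coc2c1`, differs from compound 2 by benzyl in place of phenyl on an amide-type nitrogen. Within the data shown here, the one step that bears on this change is a 2.0-fold lower number from compound 1 to compound 2 (0.31 log units; beyond the scatter), which runs in the opposite direction from the move toward compound 4. A modest rise in the number is therefore expected for compound 4, a 1.6-fold higher number from compound 2 to compound 4 (0.20 log units; within the scatter). Compound 4 is thus estimated at 22000 nM, within the range 11000 nM to 45000 nM.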

Compound 4, half-maximal inhibitory concentration: > 100000 nM
Compound 4 was reported as a limit; the forecaster's own chance of this, stated with the estimate: 5%; middle value at least 4.5-fold (0.65 log units) away from the limit.
By their numbers in this assay, from the lowest: compounds 2, 3 and 1 (each within the scatter of the next, the first and the last beyond it). At a limit, above all of these: compound 4.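

Compound 4 is reported only as a limit in this assay: the limit of > 100000 nM in this assay, at which 1 of the 4 values shown sits.

Benzyl in place of phenyl on the amide-type nitrogen gives an at least 7.1-fold higher number from compound 2 to compound 4 (0.85 log units; beyond the scatter), so the change from anilino to benzylamino is larger than the earlier step indicated. Hydrogen in place of fluoro on an aromatic carbon gives an at least 3.4-fold higher number from compound 1 to compound 4 (0.54 log units; beyond the scatter), which puts a measured number and a limit on either side of this one change.

The compounds shown leave open how far compound 4 lies past its limit. They also leave open whether a longer chain such as phenethyl on this nitrogen, or chloro in place of fluoro, gives a measured number.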